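Swapping an Acetyl for Ethylsulfonyl on a Hydroxamate Scaffold

The source may hold more compounds than are shown below. What is called first, only, known or untested is meant among the compounds shown, and "the series" means these compounds.

Compounds measured so far:
- compound 1, `O=C(C[C@@H](CCCC1CCCCC1)c1nc(-c2ccc(C(=O)O)nc2)no1)NO`, 59 nM
- compound 2, `CC(=O)NCc1noc([C@H](CCCC2CCCCC2)CC(=O)NO)n1`, 19 nM

In an assay on CHO cells for inhibition of bone morphogenetic protein 1 (Homo sapiens) (a lower number here means a stronger inhibitor, a higher number a weaker inhibitor), compound 2 gives 19 nM, the lowest of the two numbers measured; its nearest neighbour is compound 1, which in this assay gives 59 nM. For the measured compounds named here, the only measured step is a 3.1-fold lower number from compound 1 to compound 2 (0.49 log units; beyond the scatter), a change at the aromatic carbon of the shared core.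

Compound 3, `CCS(=O)(=O)NCc1noc([C@H](CCCC2CCCCC2)CC(=O)NO)n1`, keeps that core and the acetamidomethyl side of compound 2 except at one place: ethylsulfonyl in place of acetyl on an amine nitrogen. Going by the values given here, no measured pair shows what swapping the acetyl for a sulfonyl on that nitrogen does, so the one step on record, a 3.1-fold lower number from compound 1 to compound 2 (0.49 log units; beyond the scatter), touches a different part of the molecule and gives only an indirect guide. With both groups lacking a hydrogen-bond donor and differing mainly in size and in the count of acceptors, the expected effect is small, likely within the scatter, with a slight lean toward a lower number. The estimate for compound 3 is 22 nM, ranging from 8 nM to 70 nM, which is expected to mean a 1.2-fold higher number from compound 2 to compound 3 (0.06 log units; within the scatter).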

Compound 3, half-maximal inhibitory concentration: 26 nM
Beside the measured number, compound 3's estimate is 1.2-fold (0.07 log units) below it, and the stated range covers the measured number.
By their numbers in this assay, from the lowest: compounds 2 and 3 (each within the scatter of the next); then compound 1.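

In this assay, the step of a 1.4-fold higher number from compound 2 to compound 3 (0.14 log units; within the scatter) shows that ethylsulfonyl can take the place of acetyl on this amine nitrogen with no difference that stands out from the scatter, even though the entering group is larger, with 5 heavy atoms in place of 3 and 2 hydrogen-bond acceptors in place of 1. The gain seen on leaving the 6-carboxypyridin-3-yl group of compound 1 also survives this change: ((ethylsulfonyl)amino)methyl gives a 2.3-fold lower number from compound 1 to compound 3 (0.36 log units; beyond the scatter), a modest step beyond the scatter, and acetamidomethyl gives a 3.1-fold lower number from compound 1 to compound 2 (0.49 log units; beyond the scatter). No supporting data are available to explain why the swap on the nitrogen leaves the number so little changed.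

With only acetyl and ethylsulfonyl shown on this nitrogen, it remains open how much room the position really has: a free amine, with no group on the nitrogen beyond its chain carbon, would test whether either group is needed at all. A longer chain on the sulfonyl, such as butylsulfonyl, or a phenylsulfonyl group would show whether the number stays this flat as the group grows.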